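Swapping methoxy for pyrrolidine on compound 1

This account rests on a few compounds, and the source may have more. Where it says the series, first, only, none or still open, it means among the compounds named here.

Measured in a functional assay on SW480 cells (Homo sapiens) for antiproliferative activity, read by MTT assay, with a stated time of 48 h; a lower number here means a stronger inhibitor, a higher number a weaker inhibitor:
- Compound 1 `COC/C1=C/C[C@](C)(CCC=C(C)C)/C=C/[C@@H](OC(=O)C=C(C)C)[C@](C)(O)/C=C/C1=O`: 3850 nM
- Compound 2 `CC(=O)O[C@]1(C)/C=C/C(=O)/C(CO)=C\C[C@](C)(CCC=C(C)C)/C=C/[C@H]1OC(=O)C=C(C)C`: 2010 nM
- Compound 3 `CO[C@]1(C)/C=C/C(=O)/C(CO)=C\C[C@](C)(CCC=C(C)C)/C=C/[C@H]1OC(=O)C=C(C)C`: 15200 nM

In this assay, compound 1 at 3850 nM cannot be told apart from compound 2 at 2010 nM, since their gap lies within the scatter. Compound 3 gives a clearly higher number than both, at 15200 nM.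

Compound 4 `CC(C)=CCC[C@]1(C)/C=C/[C@@H](OC(=O)C=C(C)C)[C@](C)(O)/C=C/C(=O)/C(CN2CCCC2)=C\C1` keeps the core of compound 1 but carries pyrrolidin-1-yl in place of methoxy on a saturated chain carbon bound to a double-bonded ring carbon. The same difference can be read as methoxymethyl changing to (pyrrolidin-1-yl)methyl.

Within the data shown here, no measured step makes this exchange. Among the measured compounds shown here, the only measured step, a 7.6-fold higher number from compound 2 to compound 3 (0.88 log units; beyond the scatter), is a different swap, methyl in place of acetyl on an oxygen on a saturated carbon. For the measured compounds named here, it shows only that one small change can move the number well beyond the scatter, and it gives no direction for the new group. A shift of that size either way therefore stays possible, although no shift beyond the scatter is the best single expectation in this assay.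

The estimate is a 1.3-fold lower number from compound 1 to compound 4 (0.11 log units; within the scatter), a small expected step.

Compound 4 is expected near 3000 nM, with an estimated range from 700 nM to 13000 nM.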

Compound 4, half-maximal inhibitory concentration: 310 nM
For compound 4 the middle estimate is 9.7-fold (0.99 log units) above the measured one; measured number outside the range, below it.
By their numbers in this assay, from the lowest: compound 4; then compounds 2 and 1 (each within the scatter of the next); then compound 3.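

In this assay, a 12-fold lower number from compound 1 to compound 4 (1.09 log units; beyond the scatter) shows that the saturated chain carbon bound to a double-bonded ring carbon is a sensitive place on the shared core, where exchanging methoxy for pyrrolidin-1-yl moves the number well beyond the scatter towards a stronger inhibitor. Among these compounds, the earlier compounds could not show this: their only step, a 7.6-fold higher number from compound 2 to compound 3 (0.88 log units; beyond the scatter), is a swap of methyl for acetyl on an oxygen on a saturated carbon, and it says nothing about this place or about a group that brings in a nitrogen and a five-membered non-aromatic ring. Nothing available here tells which part of the change lies behind the step, whether the nitrogen, the ring or the larger group.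

With pyrrolidin-1-yl as the only amine shown at this place, it remains open whether an open-chain amine such as dimethylamino, or a six-membered ring such as piperidine or morpholine, would give a step of similar size. Also open, from the compounds shown here alone, is whether pyrrolidin-1-yl would give a similar step on a core carrying the acetyl group of compound 2 or the methyl group of compound 3 on its oxygen.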